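The source may hold more compounds than are shown below. What is called first, only, known or untested is meant among the compounds shown, and "the series" means these compounds.

Measured compounds:
compound 1, `Nc1ccccc1NC(=O)c1ccc(CSC(=S)N2CCN(C3CCCCC3)CC2)cc1`, 30.6%;
compound 2, `Nc1ccccc1NC(=O)c1ccc(CSC(=S)N2CCc3ccc([N+](=O)[O-])cc32)cc1`, 45.7%;
compound 3, `N#Cc1ccc(N2CCN(C(=S)SCc3ccc(C(=O)Nc4ccccc4N)cc3)CC2)cc1`, 71.6%.

In a functional assay on HeLa cells (Homo sapiens) for antiproliferative activity, read by CCK-8 assay, with a stated time of 72 h, tested at 2 uM (a higher number here means a stronger effect of the compound at the concentration tested, a lower number a weaker effect), compound 2 gives 45.7%, the second highest of the three numbers. Its nearest neighbour is compound 1 with 30.6%, which lies beyond the scatter below it, and the furthest is compound 3 with 71.6%, beyond the scatter above it. Among the measured compounds shown here, the only step measured between two compounds that differ in one place is a number 41 percentage points higher from compound 1 to compound 3 (beyond the scatter), and that change concerns a different part of the shared core than the one now in question.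

Compound 4, `Nc1ccccc1NC(=O)c1ccc(CSC(=S)N2CCc3ccccc32)cc1`, has not yet been measured in this assay. It differs from compound 2 by hydrogen in place of nitro on an aromatic carbon. No measured pair shows this change, so the direction of the step has to be estimated without a direct precedent; the measured compounds give no reason to expect a large step either way. Compound 4 is therefore estimated at 38%, within a range of 18% to 58%, a step of a number 7.7 percentage points lower from compound 2 to compound 4 (within the scatter) that is expected to fall roughly within the scatter.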

Compound 4, a percentage reported as inhibition, at one concentration (the size of the read-out at that concentration, not a potency): 38%
The estimate for compound 4 equals the measured number at the digits printed; measured number inside the range.
By their numbers in this assay, from the lowest: compounds 1, 4 and 2 (each within the scatter of the next, the first and the last beyond it); then compound 3.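

Replacing nitro with hydrogen on this aromatic carbon, which is meta to a fused ring and para to a fused ring, gives in this assay the only step shown at this position: a number 7.7 percentage points lower from compound 2 to compound 4 (within the scatter). The earlier compounds shown here said nothing about this place, and the new pair shows that the whole nitro group, with its 3 heavy atoms, can give way to a single hydrogen without a change that stands clear of the usual scatter at the one concentration tested. Nothing among the data given explains this result or says what part, if any, the nitro group plays in the reading for compound 2.

On these data alone, what an amine, a methoxy group or a chlorine atom on the same aromatic carbon would give remains open, as does whether nitro on another carbon of this ring would read like hydrogen. Also open, as far as these compounds go, is whether the swap of nitro for hydrogen would look the same at other concentrations, where the effect could prove stronger or weaker than the one seen at the single concentration tested.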